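The source may hold more compounds than are shown below. What is called first, only, known or untested is meant among the compounds shown, and "the series" means these compounds.

Among the compounds with values here, the three compounds measured so far share a core in which a six-membered ring bearing an amide-type nitrogen is fused to an aromatic ring. Compound 1 `CC(C)N1C(=O)COc2ccc(-c3cccc(NS(=O)(=O)c4ccc(F)cc4)c3)cc21` carries an isopropyl group on that nitrogen, and in a functional assay on HCT-116 cells (Homo sapiens) for antiproliferative activity, read by MTT assay, with a stated time of 72 h (a higher number here means a weaker inhibitor, a lower number a stronger inhibitor), compound 1 gives 22600 nM. Compound 3 `O=C1COc2ccc(-c3cccc(NS(=O)(=O)c4ccc(F)cc4)c3)cc2N1C1CCCCC1` carries a cyclohexyl group instead, and in this assay compound 3 gives 18300 nM; the move a 1.2-fold lower number from compound 1 to compound 3 (0.09 log units; within the scatter) shows that swapping one saturated group for another on this nitrogen leaves the read-out essentially where it was. Compound 2 `O=C1COc2ccc(-c3cnc4ccccc4c3)cc2N1C1CCCCC1` keeps the cyclohexyl group but carries a different aromatic substituent on the core. In this assay compound 2 gives > 40000 nM, which is a limit of the assay rather than a measured number, as noted in the limit of > 40000 nM in this assay, at which 1 of the 3 values shown sits.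

Compound 4 `O=C1COc2ccc(-c3cnc4ccccc4c3)cc2N1c1ccccc1` is compound 2 with phenyl in place of cyclohexyl on an amide-type nitrogen in a ring. Within the data shown here, the only measured step that touches the same nitrogen is the one from compound 1 to compound 3, and it lies within the scatter, so no shift beyond the scatter is expected here either. Compound 4 is therefore expected to stay near the limit, with an estimated 40000 nM in this assay, ranging from 12000 nM to 120000 nM, a step of a number no higher from compound 2 to compound 4 (the limit leaves the size open) from compound 2.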

Compound 4, half-maximal inhibitory concentration: > 40000 nM
Compound 4 ended at the assay's limit; the forecaster's own chance of this, stated with the estimate: 65%; the middle value sits exactly at the limit.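

Compound 2 and compound 4 both end at a limit of this assay rather than at a number, so the step between them cannot be read: the limit of > 40000 nM in this assay, at which 2 of the 4 values shown sit.

The compounds shown leave open whether phenyl and cyclohexyl on this nitrogen differ at all when the core carries this aromatic substituent, and how weak either compound really is.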